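Swapping Pyrimidin-2-yl for Pyridazin-3-yl: An Estimate

This account rests on a few compounds, and the source may have more. Where it says the series, first, only, none or still open, it means among the compounds named here.

Compound 1, `COc1ccccc1C(=O)Nc1ccc(Cl)cc1CN1C(=O)c2ccccc2C1=O`, gives < 1000 nM in an assay on CHO cells for positive allosteric modulation of metabotropic glutamate receptor 5 (Rattus norvegicus), read by FLIPR (on this read-out lower numbers stand for an effect already at smaller amounts and higher numbers for an effect only at larger amounts of compound), a limit of the assay rather than a number.
Compound 2, `O=C(Nc1ccc(Cl)cc1CN1C(=O)c2ccccc2C1=O)c1ccccc1`, gives < 1000 nM in this assay, again a limit of the assay.
Compound 3, `O=C(Nc1ccc(Cl)cc1CN1C(=O)c2ccccc2C1=O)c1ncccn1`, gives < 1000 nM in this assay, also only a limit of the assay.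

Compounds 1, 2 and 3 share one core and differ only in the group on the carbonyl carbon: 2-methoxyphenyl, phenyl and pyrimidin-2-yl. Compound 3 therefore sits at the limit of < 1000 nM in this assay, at which 3 of the 3 values shown sit, with the two other values at the same limit, so its standing relative to them cannot be read. The steps a step that the two limits leave unreadable from compound 1 to compound 2, a step that the two limits leave unreadable from compound 1 to compound 3 and a step that the two limits leave unreadable from compound 2 to compound 3 are all hidden by the limit, so no size can be taken from them.

Compound 4, `O=C(Nc1ccc(Cl)cc1CN1C(=O)c2ccccc2C1=O)c1cccnn1`, is not yet measured. It differs from compound 3 by pyridazin-3-yl in place of pyrimidin-2-yl on a carbonyl carbon. Since every step measured so far is unreadable, the step that the limit leaves unreadable from compound 3 to compound 4 is expected to be small, with no direction established. The estimate for compound 4 in this assay is 300 nM, within a range from 30 nM to 2500 nM, and it is expected that the assay may again report only a limit.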

Compound 4, half-maximal effective concentration: < 1000 nM
Compound 4 gave a limit, no number; the forecaster's own chance of this, stated with the estimate: 60%; the middle value is on the limit's open side.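

Compound 4, like compound 1, compound 2 and compound 3, gives only a limit of the assay, so none of the steps among these four compounds can be read: the limit of < 1000 nM in this assay, at which 4 of the 4 values shown sit.

On these data alone, whether the groups on the carbonyl carbon differ at all in this assay stays open, as does the size of any such difference.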